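This account rests on a few compounds, and the source may have more. Where it says the series, first, only, none or still open, it means among the compounds named here.

In a functional assay on MIA PaCa-2 cells (Homo sapiens) for inhibition, read by MTT assay, with a stated time of 72 h (on this read-out higher numbers stand for weaker inhibition and lower numbers for stronger inhibition), compound 2 `COc1cc(NC(C)CCCNC(=O)Nc2cccc(O)c2)c2ncccc2c1` gives 46000 nM and compound 3 `COc1cc(NC(C)CCCNC(=O)NNC(=O)Nc2cccc(F)c2)c2ncccc2c1` gives 69000 nM, two values within the usual scatter of each other. Compound 1 `COc1cc(NC(C)CCCNC(=O)NNC(=O)Nc2ccc(Cl)cc2)c2ncccc2c1` gives >= 250000 nM, which is a limit of this assay and not a number. Compound 3 therefore stands level with compound 2, and both are clearly stronger than compound 1.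

Compound 4 `COc1cc(NC(C)CCCNC(=O)NNC(=O)Nc2ccc(O)cc2)c2ncccc2c1` differs from compound 3 at a single place: 4-hydroxyphenyl in place of 3-fluorophenyl on an amide-type nitrogen. In words, this is 4-hydroxyphenyl in place of 3-fluorophenyl on an amide-type nitrogen.

Within the data shown here, two measured steps bear on this change. The first, an at least 3.6-fold lower number from compound 1 to compound 3 (0.55 log units; beyond the scatter), exchanges 4-chlorophenyl for 3-fluorophenyl at the same place, so the group there can matter. The second, a 1.5-fold higher number from compound 2 to compound 3 (0.18 log units; within the scatter), lies within the scatter, so the hydroxyl-bearing compound 2 and the fluorine-bearing compound 3 cannot be told apart. Neither step isolates a hydroxyl group in the 4-position, and compound 1, with its 4-chlorophenyl, gives only a limit, so a slight drift toward weaker inhibition seems likelier than a gain.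

The expected change is a 1.3-fold higher number from compound 3 to compound 4 (0.12 log units; within the scatter), which is not expected to clearly exceed the scatter. For compound 4 the estimated value is 90000 nM, with an expected range from 35000 nM to 230000 nM.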

Compound 4, half-maximal inhibitory concentration: 142000 nM
Estimate against measurement, compound 4: 1.6-fold (0.20 log units) below, and the stated range covers the measured number.
By their numbers in this assay, from the lowest: compounds 2 and 3 (each within the scatter of the next); then compound 4. At a limit, above all of these: compound 1.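

In this assay, the aryl group on this amide-type nitrogen now shows an effect between two measured numbers and not only against a limit: a 2.1-fold higher number from compound 3 to compound 4 (0.31 log units; beyond the scatter), with 4-hydroxyphenyl in place of 3-fluorophenyl. A hydroxyl on the aromatic ring does not by itself keep a compound at the level of compound 2, as a 3.1-fold higher number from compound 2 to compound 4 (0.49 log units; beyond the scatter), where ((4-hydroxyphenyl)carbamoyl)amino stands in place of 3-hydroxyphenyl. The remaining step, an at least 1.7-fold lower number from compound 1 to compound 4 (0.24 log units; that floor lies within the scatter), has hydroxy in place of chloro, but it rests on a limit and cannot be read as a gain: the limit of >= 250000 nM in this assay, at which 1 of the 4 values shown sits.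

The compounds shown do not separate the identity of the group from its place on the ring, since compound 3 and compound 4 differ in both; a 3-hydroxyphenyl or a 4-fluorophenyl on the same nitrogen would pull these two apart. From the compounds shown here alone, it also remains open how an amine or a carboxylic acid in the 4-position of that ring would compare with the hydroxyl of compound 4.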